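The source may report more compounds than this note shows. Statements on the series, on what has been measured and on what is new or still open speak of the compounds shown alone.

Measured in a functional assay on MCF7 cells (Homo sapiens) for antiproliferative activity, read by MTT assay, with a stated time of 72 h; on this read-out lower numbers stand for stronger inhibition and higher numbers for weaker inhibition:
compound 1, `O=C1O[C@H]([C@@H](O)Cn2cc(CCCCl)nn2)C(OCc2ccccc2)=C1OCc1ccccc1`, gives 24500 nM
compound 2, `C[Si](C)(C)c1cn(C[C@H](O)[C@H]2OC(=O)C(OCc3ccccc3)=C2OCc2ccccc2)nn1`, gives 12100 nM

Among the measured compounds shown here, compound 2 holds the lower of the two numbers in this assay; compound 1 is its only neighbour, and the step of a 2.0-fold lower number from compound 1 to compound 2 (0.31 log units; beyond the scatter) separates them. Compound 3, `COc1ccc(-c2cn(C[C@H](O)[C@H]3OC(=O)C(OCc4ccccc4)=C3OCc3ccccc3)nn2)cc1`, is not yet measured. It differs from compound 2 by a group of 8 heavy atoms (7 carbon, 1 oxygen; one six-membered aromatic ring of carbon only) in place of a group of 4 heavy atoms (3 carbon, 1 silicon; no ring), on an aromatic carbon; the entering 4-methoxyphenyl sits on an aromatic carbon of the five-membered aromatic ring with 3 nitrogen. For the measured compounds named here, the one measured step at this place, a 2.0-fold lower number from compound 1 to compound 2 (0.31 log units; beyond the scatter), was modest, and both groups compared there had no ring; no measured compound carries an aromatic ring at this place. The change to compound 3 is therefore a larger departure than anything measured, with direction unknown, and the expected step is set near neutral as a 1.2-fold lower number from compound 2 to compound 3 (0.08 log units; within the scatter). Compound 3 is accordingly estimated at 10000 nM, with a range of 3000 nM to 40000 nM.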

Compound 3, half-maximal inhibitory concentration: 99700 nM
Compound 3: middle estimate off by 10-fold (1.00 log units), on the low side; measured number outside the range, above it.
By their numbers in this assay, from the lowest: compound 2; then compound 1; then compound 3.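

Working in this assay, the first aromatic ring at this aromatic carbon of the five-membered ring moves the number upward, with an 8.2-fold higher number from compound 2 to compound 3 (0.92 log units; beyond the scatter) and a 4.1-fold higher number from compound 1 to compound 3 (0.61 log units; beyond the scatter). Thus 4-methoxyphenyl, the only ring-bearing group here, gives weaker inhibition than both 3-chloropropyl and the silicon-bearing group, and both steps exceed the one earlier step at this place, a 2.0-fold lower number from compound 1 to compound 2 (0.31 log units; beyond the scatter). No available evidence accounts for this change.

From the compounds shown here alone, the three compounds cannot separate the contribution of the phenyl ring from that of its methoxy group, so plain phenyl and 4-hydroxyphenyl remain open comparisons. Going by these compounds, it also remains open how a longer alkyl chain or a chain ending in an amine would compare with 3-chloropropyl at this aromatic carbon.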